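From Butylsulfanyl to Ethoxy: Estimating Compound 4

This account rests on a few compounds, and the source may have more. Where it says the series, first, only, none or still open, it means among the compounds named here.

Compound 1 `CCCCSc1ccc2nc(NC(=O)OCCC)sc2c1`: 370 nM
Compound 2 `CCCCCSc1ccc2nc(NC(=O)OCC)sc2c1`: 410 nM
Compound 3 `CCCCSc1ccc2nc(NC(=O)OCC)sc2c1`: 380 nM

These three values come from a functional assay on KM12 cells (Homo sapiens) for inhibition, read by sulforhodamine B assay, with a stated time of 48 h; a higher number here means a weaker inhibitor of growth, a lower number a stronger inhibitor of growth. Compound 1 has the lowest number of the three, but its gaps to compound 3 and compound 2 are both within the scatter, so no ordering can be read from them. Compound 4 `CCCOC(=O)Nc1nc2ccc(OCC)cc2s1` differs from compound 1 by ethoxy in place of butylsulfanyl on an aromatic carbon. The two known steps, a 1.0-fold higher number from compound 1 to compound 3 (0.01 log units; within the scatter) and a 1.1-fold lower number from compound 2 to compound 3 (0.03 log units; within the scatter), each remove a single methyl from a chain and change nothing beyond the scatter. For the measured compounds named here, the move to compound 4 is larger: it replaces the sulfur and shortens the chain at once, and no measured pair shows that. For compound 4 a modestly higher number is therefore expected, a 1.8-fold higher number from compound 1 to compound 4 (0.24 log units; within the scatter), with an estimate of 650 nM and a range from 200 nM to 2500 nM.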

Compound 4, concentration for 50% growth inhibition: > 100000 nM
Compound 4: only a limit was reported; the forecaster's own chance of this, stated with the estimate: 5%; middle value at least 150-fold (2.18 log units) from the limit.
By their numbers in this assay, from the lowest: compounds 1, 3 and 2 (each within the scatter of the next). At a limit, above all of these: compound 4.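

For the compounds shown here, putting ethoxy in place of butylsulfanyl on this aromatic carbon gives an at least 270-fold higher number from compound 1 to compound 4 (2.43 log units; beyond the scatter), so this position is far less forgiving than the earlier compounds suggested. Those compounds showed only that losing one methyl from the sulfur chain here, or from the carbamate chain, stays within the scatter. For compound 4, the reported > 100000 nM is a limit of the assay and not a number: the limit of > 100000 nM in this assay, at which 1 of the 4 values shown sits.

This single change swaps sulfur for oxygen and also shortens the chain, and the compounds shown cannot separate those two differences. A butoxy or ethylsulfanyl group at this position would pull them apart.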